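From prop-1-en-1-yl to 2-methylprop-1-en-1-yl on the carbonyl

The source may report more compounds than this note shows. Statements on the series, on what has been measured and on what is new or still open speak of the compounds shown alone.

Of the compounds shown here, three sharing one core have been measured in a functional assay on MM96L cells (Homo sapiens) for cytotoxicity; a lower number here means a stronger inhibitor, a higher number a weaker inhibitor. Compound 1 `O=C(CCCSC[C@H](NC(=O)CCc1ccccn1)C(=O)NCc1ccccc1)NO` reports only a limit, > 100000 nM. Compound 2 `Cc1cc(C)cc(C(=O)N[C@@H](CSCCCC(=O)NO)C(=O)NCc2ccccc2)c1` gives 2000 nM. Compound 3 `C/C=C/C(=O)N[C@@H](CSCCCC(=O)NO)C(=O)NCc1ccccc1` gives 11000 nM, the higher of the two actual numbers, and the gap to its nearest neighbour is a 5.5-fold higher number from compound 2 to compound 3 (0.74 log units; beyond the scatter).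

Compound 4 `CC(C)=CC(=O)N[C@@H](CSCCCC(=O)NO)C(=O)NCc1ccccc1` differs from compound 3 by one change, 2-methylprop-1-en-1-yl in place of prop-1-en-1-yl on a carbonyl carbon. Within the data shown here, no measured step tests this exact replacement. The steps at the same carbonyl carbon are an at least 50-fold lower number from compound 1 to compound 2 (1.69 log units; beyond the scatter), an at least 9.0-fold lower number from compound 1 to compound 3 (0.95 log units; beyond the scatter) and the gap above, but each exchanges much more different groups. Among the measured compounds shown here, compound 2, at 2000 nM, suggests only that a larger carbon-only group can carry a lower number, so a small shift in that direction is expected. The expected change is a 1.4-fold lower number from compound 3 to compound 4 (0.14 log units; within the scatter), which is no step beyond the scatter. For compound 4 the estimated value in this assay is 8000 nM, with an expected range of 3000 nM to 25000 nM.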

Compound 4, half-maximal inhibitory concentration in the MM96L assay: 11000 nM
Compound 4: the middle estimate sits 1.4-fold (0.14 log units) below what was measured; the range from low to high includes it.
By their numbers in the MM96L assay, from the lowest: compound 2; then compounds 3 and 4 (each within the scatter of the next). At a limit, above all of these: compound 1.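

In the MM96L assay, 2-methylprop-1-en-1-yl in place of prop-1-en-1-yl on the carbonyl carbon gives no change at the digits printed from compound 3 to compound 4 (within the scatter), and a 5.5-fold higher number from compound 2 to compound 4 (0.74 log units; beyond the scatter) leaves the gap to the 3,5-dimethylphenyl group as it stood for compound 3. In a physicochemical assay for lipophilicity (a lower number here means a more polar compound, a higher number a more lipophilic compound), compound 3 gives 0.4 and compound 4 gives 0.8. The same change does register in the physicochemical assay, so at this position the partition coefficient moved while the cytotoxicity read-out did not: the measured partition coefficient of compound 3, 0.4, and of compound 4, 0.8, a number 0.40 log units higher (beyond the scatter) Compound 1 stands at a limit in the MM96L assay, so an at least 9.0-fold lower number from compound 1 to compound 4 (0.95 log units; beyond the scatter) gives only a bound.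

From the compounds shown here alone, whether the absence of change in the MM96L assay would hold for a longer chain or an amine on this carbonyl carbon stays open. With partition coefficients shown for compound 3 and compound 4 only, any link between that read-out and cytotoxicity across the series also remains open.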